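The source may hold more compounds than are shown below. What is called first, only, known or untested is meant among the compounds shown, and "the series" means these compounds.

Measured so far, in a functional assay for inhibition of sodium/hydrogen exchanger (Oryctolagus cuniculus); a higher number here means a weaker inhibitor, a lower number a stronger inhibitor:

Compound 1 `Cc1cc(C)c(S(C)(=O)=O)cc1C(=O)N=C(N)N` gives 11 nM in this assay.
Compound 2 `Cc1cc(C2CCCCC2)c(S(C)(=O)=O)cc1C(=O)N=C(N)N` gives 22 nM.
Compound 3 `Cc1cc(Sc2ccccc2Cl)c(S(C)(=O)=O)cc1C(=O)N=C(N)N` gives 14 nM.

Compound 3 stands second highest of the three numbers; its nearest neighbour is compound 1, its furthest compound 2, and both gaps lie within the scatter. The three compounds differ only in the group on one aromatic carbon of the shared core: methyl, cyclohexyl or (2-chlorophenyl)sulfanyl all give numbers that cannot be told apart, as the steps show: a 2.0-fold higher number from compound 1 to compound 2 (0.30 log units; within the scatter), a 1.3-fold higher number from compound 1 to compound 3 (0.10 log units; within the scatter), a 1.6-fold lower number from compound 2 to compound 3 (0.20 log units; within the scatter).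

Compound 4 `Cc1cc(N2CCCC(O)C2)c(S(C)(=O)=O)cc1C(=O)N=C(N)N` is not yet measured. It differs from compound 3 as follows: 3-hydroxypiperidin-1-yl in place of (2-chlorophenyl)sulfanyl on an aromatic carbon. All three measured steps bear on this position, and none of them is beyond the scatter, which argues for a small change. Among the measured compounds shown here, the entering 3-hydroxypiperidin-1-yl, though, brings a hydrogen-bond donor and a non-aromatic ring with a hetero atom, and no measured compound has anything of that kind at this position, so the expectation is held more loosely than for the steps already seen.

Compound 4 is expected to land near the measured three, with the estimated step of a 1.4-fold higher number from compound 3 to compound 4 (0.15 log units; within the scatter) giving an expected value of 20 nM, in the range 6 nM to 70 nM.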

Compound 4, half-maximal inhibitory concentration: 30 nM
For compound 4 the middle estimate is 1.5-fold (0.18 log units) below the measured one; measured number inside the range.
By their numbers in this assay, from the lowest: compounds 1, 3, 2 and 4 (each within the scatter of the next, the first and the last beyond it).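

In this assay, among the compounds shown here, 3-hydroxypiperidin-1-yl on this aromatic carbon, ortho to the methylsulfonyl group, gives the only steps at this position that pass beyond the scatter (a 2.1-fold higher number from compound 3 to compound 4 (0.33 log units; beyond the scatter) and a 2.7-fold higher number from compound 1 to compound 4 (0.44 log units; beyond the scatter)), both of them modest. Compound 2 goes against any reading of this as a clear loss for the new group, since the step from cyclohexyl stays inside the scatter (a 1.4-fold higher number from compound 2 to compound 4 (0.13 log units; within the scatter)), so the position tolerates a non-aromatic ring carrying a hetero atom and a hydrogen-bond donor with only a limited shift in the number. No accompanying measurement bears on this result, and the numbers alone do not tie the shift to any feature of the entering group.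

The compounds shown leave open whether the hydroxyl group or the ring nitrogen matters here, a question that piperidin-1-yl, 4-hydroxypiperidin-1-yl and morpholin-4-yl at the same carbon would address. They also leave open how this position responds to an open-chain amine such as dimethylamino, or to a carboxylic acid carried on a short chain.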